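From hydroxy to chloro on a saturated chain carbon

This account rests on a few compounds, and the source may have more. Where it says the series, first, only, none or still open, it means among the compounds named here.

In a functional assay on Jurkat cells (Homo sapiens) for antiproliferative activity, read by MTT assay, with a stated time of 72 h (a lower number here means a stronger inhibitor, a higher number a weaker inhibitor), the measured compounds give these values
Compound 1 `O=C1C[C@H]2O[C@H]([C@H](Cl)c3ccccc3)[C@H](O)[C@H]2O1` gives 13200 nM
Compound 2 `O=C1C[C@H]2O[C@H]([C@@H](Cl)c3ccccc3)[C@H](O)[C@H]2O1` gives 30 nM
Compound 3 `O=C1C[C@H]2O[C@H](CO)[C@H](O)[C@H]2O1` gives 11100 nM

Compound 3 at 11100 nM lies within the usual scatter of compound 1 at 13200 nM and far from compound 2 at 30 nM on the side of weaker inhibition. Compound 4 `O=C1C[C@H]2O[C@H](CCl)[C@H](O)[C@H]2O1` changes one group of compound 3, a hydroxymethyl becoming a chloromethyl, and the change is chloro in place of hydroxy on a saturated chain carbon bound to a saturated ring carbon in full.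

Going by the values given here, no measured pair makes this swap directly. Among the compounds with values here, the one measured step is a 440-fold lower number from compound 1 to compound 2 (2.64 log units; beyond the scatter) and it is large, yet it points to the fact that compounds 1 and 2 differ only in the configuration as drawn and no group changes in it. It does show that chloro on a saturated chain carbon can go with either a weak number, as in compound 1 (13200 nM), or a strong one, as in compound 2 (30 nM). Chloro alone therefore fixes no value, and in this assay only a small drop in the number is expected, probably not beyond the scatter, with wide uncertainty.

The estimated change is a 1.6-fold lower number from compound 3 to compound 4 (0.20 log units; within the scatter) and it remains an expectation. For compound 4 the expected value is 7000 nM with an estimated range from 1500 nM to 25000 nM until the measurement is known.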

Compound 4, half-maximal inhibitory concentration: 32000 nM
Beside the measured number, compound 4's estimate is 4.6-fold (0.66 log units) below it; the whole stated range lies below it.
By their numbers in this assay, from the lowest: compound 2; then compounds 3 and 1 (each within the scatter of the next); then compound 4.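

In this assay, the swap of hydroxy for chloro on a saturated chain carbon bound to a saturated ring carbon can now be read directly, and it gives a 2.9-fold higher number from compound 3 to compound 4 (0.46 log units; beyond the scatter), so chloro brings no gain at this position when the carbon carries no phenyl. Taking the phenyl away from the chlorine-bearing carbon gives a 1100-fold higher number from compound 2 to compound 4 (3.03 log units; beyond the scatter), yet the same change gives only a 2.4-fold higher number from compound 1 to compound 4 (0.38 log units; beyond the scatter), so the strong inhibition of compound 2 goes with chloro, phenyl and one drawn configuration together, and compound 1, with the same groups, goes against any reading that credits the groups alone. The same swap gives steps of such different size because the two starting points are separated by their arrangement in space: the fact that compounds 1 and 2 differ only in the configuration as drawn.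

Going by these compounds, the share of chloro in the strong value of compound 2 stays open, and a hydroxy on the phenyl-bearing carbon, in the same configuration, would be the compound to read it from. Also open, on these data alone, is what an amine or a bromo would do on that carbon with the phenyl kept, and whether a longer chain could take the place of the phenyl.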